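The compounds below may be only part of what the source reports. "The series", "measured", "known", "first", "only" and "open" are said of these compounds alone.

Measured compounds:

compound 1, `COc1ccc(N)c(C(O)CCNC(=N)c2ccccc2)c1`: 95.9%
compound 2, `COc1ccc(N)c(C(O)CCNC(=N)c2ccc(Cl)cc2)c1`: 81%
compound 3, `CC(=N)NCCC(=O)c1ccccc1N`: 22.3%

The read-out throughout is an assay for inhibition of Nitric oxide synthase, inducible (Homo sapiens), with a stated time of 30 min, tested at 1 mM; on this read-out lower numbers stand for less inhibition and higher numbers for more inhibition at the one concentration tested (going by the name of the read-out). In this assay compound 1 gives 95.9%, and compound 2, which differs from it by chloro in place of hydrogen on an aromatic carbon, gives 81%. That single change produced a number 14.9 percentage points lower from compound 1 to compound 2 (beyond the scatter).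

Compound 3 stands lowest of the three, well beyond the scatter from both compound 2 and compound 1; the difference between its core and the core of compound 1 is not broken down here.

Compound 4, `CC(=N)NCCC(=O)c1cc(Cl)ccc1N`, has not yet been measured. It differs from compound 3 by chloro in place of hydrogen on an aromatic carbon. Among the measured compounds shown here, this is the same kind of change as the one from compound 1 to compound 2, but not the same: in compound 2 the chloro sits para to a large group, whereas in compound 4 it sits meta to a group of 8 heavy atoms and para to an amino group, on a different core.

For the measured compounds named here, the earlier step is the only guide. On that basis the expected step is a number 10.3 percentage points lower from compound 3 to compound 4 (beyond the scatter), in the same direction but smaller, because compound 3 already gives only 22.3% and the read-out cannot fall far. Compound 4 is therefore estimated at 12%, most likely between 0% and 35%.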

Compound 4, a percentage reported as inhibition, at one concentration (the size of the read-out at that concentration, not a potency): 99.1%
Compound 4: the middle estimate sits 87.1 percentage points below what was measured; measured number above the stated range.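

In this assay, putting chloro in place of hydrogen on an aromatic carbon gives a number 76.8 percentage points higher from compound 3 to compound 4 (beyond the scatter), so a single added atom turns one of the lowest readings in this set into one of the highest. This shows that the effect of the change cannot simply be carried from one core to another in this series, since the same swap moves the number in opposite directions on the two cores: the same change on two cores in this assay, a number 14.9 percentage points lower (beyond the scatter) from compound 1 to compound 2 and a number 76.8 percentage points higher (beyond the scatter) from compound 3 to compound 4, 91.7 percentage points apart, beyond the scatter of two such steps It does not show which difference between the two pairs is responsible, as the cores differ and the chloro does not occupy the same kind of place in each, and two steps alone offer no rule for predicting the effect on a third core.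

The compounds shown leave open whether this jump depends on chlorine itself, which a fluoro, a bromo or a nitrile in the same place on the core of compound 3 could test. Also open, on these data alone, is whether chloro in another place on that core would behave alike, and how compound 4 would read at other concentrations, as a single concentration does not give a potency.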